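From piperidin-4-yl to a methylsulfonyl-piperazinyl ethyl chain

A few compounds are considered here, and "the series" means these few. Any claim that something is new, unique, unknown or untested is made for them only; others in the source may bear on it.

Compound 1 `c1cc([C@H]2CC[C@]3(CC2)OOC2(O3)C3CC4CC(C3)CC2C4)ccc1OCC1CCNCC1`: in an ADME assay on microsomes from liver (Homo sapiens) for metabolic stability, read by LC-MS, tested at 1 uM (a higher number here means faster removal of the compound, a lower number slower removal), compound 1 gives < 7 mL.min-1.g-1, a limit of the assay rather than a number.
Compound 2 `c1cc([C@H]2CC[C@]3(CC2)OOC2(O3)C3CC4CC(C3)CC2C4)ccc1OCCC1CCNCC1`: in this assay compound 2 gives < 7 mL.min-1.g-1, also a limit.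
Compound 3 `NCCOCCOc1ccc([C@H]2CC[C@]3(CC2)OOC2(O3)C3CC4CC(C3)CC2C4)cc1`: in this assay compound 3 gives < 7 mL.min-1.g-1, again a limit.

Compound 1 therefore stands only at a limit, and so do both neighbours; (the limit of < 7 mL.min-1.g-1 in this assay, at which 3 of the 3 values shown sit). Compound 4 `CS(=O)(=O)N1CCN(CCCOc2ccc([C@H]3CC[C@]4(CC3)OOC3(O4)C4CC5CC(C4)CC3C5)cc2)CC1` carries the change (2-(4-(methylsulfonyl)piperazin-1-yl)ethyl in place of piperidin-4-yl on a saturated chain carbon bound to an oxygen on an aromatic ring). The steps a step that the two limits leave unreadable from compound 1 to compound 2 and a step that the two limits leave unreadable from compound 1 to compound 3 touch the same carbon, yet neither can be sized, so no direction can be read from them. Compound 4 is expected to show a number no lower from compound 1 to compound 4 (the limit leaves the size open), most likely ending at the limit again. The estimate for compound 4 in this assay is 7 mL.min-1.g-1, within 3 mL.min-1.g-1 to 20 mL.min-1.g-1.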

Compound 4, intrinsic clearance in microsomes: 68 mL.min-1.g-1
For compound 4 the middle estimate is 9.7-fold (0.99 log units) below the measured one; the whole stated range lies below it.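

In this assay, the saturated chain carbon bound to an oxygen on an aromatic ring proves sensitive to what it carries: 2-(4-(methylsulfonyl)piperazin-1-yl)ethyl gives an at least 9.7-fold higher number from compound 1 to compound 4 (0.98 log units; beyond the scatter). The other neighbours show the same, with an at least 9.7-fold higher number from compound 2 to compound 4 (0.98 log units; beyond the scatter) and an at least 9.7-fold higher number from compound 3 to compound 4 (0.98 log units; beyond the scatter), while the steps among compounds 1, 2 and 3 cannot be read. Compound 4 alone leaves the limit: the limit of < 7 mL.min-1.g-1 in this assay, at which 3 of the 4 values shown sit.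

As far as these compounds go, it remains open whether the methylsulfonyl group or the piperazine ring carries this rise. A plain piperazine, an acetyl on that ring nitrogen or a morpholine could separate the two.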